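The compounds below may be only part of what the source reports. "The series", "measured", "known", "first", "only" and "open" are said of these compounds alone.

In a functional assay on HT-29 cells (Homo sapiens) for cytotoxicity, read by MTT assay, with a stated time of 24 h, tested at 16 ug/mL (a lower number here means a weaker effect, a higher number a stronger effect of the compound at the concentration tested), compound 2 `Cn1c(-c2ccc(NC(=O)CN3CCN(Cc4ccccc4)CC3)cc2)nc(-c2ccccc2)c1-c1ccccc1` gives 37%. For the measured compounds named here, its only measured neighbour, compound 1 `CN1CCN(CC(=O)Nc2ccc(-c3nc(-c4ccccc4)c(-c4ccccc4)n3C)cc2)CC1`, gives 33.7% in this assay, and the step of a number 3.3 percentage points higher from compound 1 to compound 2 (within the scatter) stays within the scatter, so the two compounds cannot be told apart on these numbers, and compound 2 has no read-out that sets it above or below compound 1. Compound 3 `COc1ccc(CN2CCN(CC(=O)Nc3ccc(-c4nc(-c5ccccc5)c(-c5ccccc5)n4C)cc3)CC2)cc1` differs from compound 2 by methoxy in place of hydrogen on an aromatic carbon. Going by the values given here, the single measured step concerns a different place in the molecule, a saturated chain carbon rather than an aromatic carbon, and it was small, so no measured step speaks directly to the change on the aromatic carbon. The account therefore expects the step of no change at the digits printed from compound 2 to compound 3 (within the scatter) to stay within the scatter, with no direction claimed. Compound 3 is estimated at 37%, within a range from 22% to 52%.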

Compound 3, a percentage reported as activity, at one concentration (the size of the read-out at that concentration, not a potency): 21.8%
Compound 3: the middle estimate sits 15.2 percentage points above what was measured; measured number outside the range, below it.
By their numbers in this assay, from the lowest: compound 3; then compounds 1 and 2 (each within the scatter of the next).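

In this assay, for the compounds shown here, the aromatic carbon of the benzyl group proves responsive to substitution: methoxy in place of hydrogen gives a number 15.2 percentage points lower from compound 2 to compound 3 (beyond the scatter), the first step to pass the scatter. With 4-methoxyphenyl in place of hydrogen on the saturated chain carbon, the series shows a number 11.9 percentage points lower from compound 1 to compound 3 (beyond the scatter), which makes compound 3 the weakest of the three at the concentration tested, whereas the unsubstituted phenyl of compound 2 could not be told apart from compound 1. Nothing measured here accounts for this drop.

The compounds shown leave open whether the drop is specific to methoxy or would also follow from another group on that aromatic carbon, such as a hydroxyl, a chlorine or an ethoxy group. They also leave open whether a longer chain between the phenyl ring and the ring nitrogen would change the outcome.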